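Chain extension on the methylindole amide in the cytotoxicity series

A few compounds are considered here, and "the series" means these few. Any claim that something is new, unique, unknown or untested is made for them only; others in the source may bear on it.

Measured so far in a functional assay on HepG2 cells (Homo sapiens) for cytotoxicity, read by MTT assay, with a stated time of 48 h; a higher number here means a weaker inhibitor, a lower number a stronger inhibitor:
compound 1 `CCCCCCCCCCCCNC(=O)[C@@H](NC(=O)c1cc2ccccc2o1)[C@@H](C)O` gives 22900 nM
compound 2 `CCCCCCCCCCCCNC(=O)[C@@H](NC(=O)c1cc2ccccc2n1C)[C@@H](C)O` gives only a limit, > 200000 nM
compound 3 `C/C=C/C=C/C(=O)N[C@H](C(=O)NCCCCCCCCCCCC)[C@@H](C)O` gives only a limit, > 400000 nM

Compound 2 stands at a limit of this assay; of the three values shown, one other is also a limit (the limit of > 400000 nM in this assay, at which 1 of the 3 values shown sits). Among the measured steps, an at least 8.7-fold higher number from compound 1 to compound 2 (0.94 log units; beyond the scatter) and an at least 17-fold higher number from compound 1 to compound 3 (1.24 log units; beyond the scatter), while a step that the two limits leave unreadable from compound 2 to compound 3.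

Compound 4 `CCCCCCCCCCCCCCCCCCNC(=O)[C@@H](NC(=O)c1cc2ccccc2n1C)[C@@H](C)O` differs from compound 2 by hexyl in place of hydrogen on a saturated chain carbon, ten or more bonds along the chain from an amide-type nitrogen. Among the measured compounds shown here, no measured step changes the chain, so none bears on this change. Compound 2 already sits at a limit, so compound 4 is expected to remain there too, with a number no higher from compound 2 to compound 4 (the limit leaves the size open) estimated. Compound 4 is estimated at 200000 nM, expected between 100000 nM and 400000 nM.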

Compound 4, half-maximal inhibitory concentration: > 200000 nM
Compound 4: no number, only a limit; the forecaster's own chance of this, stated with the estimate: 80%; the middle value lies on the limit itself.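

Compound 2 and compound 4 both stand at a limit, and no step can be read between them. The compounds shown leave open whether hexyl in place of hydrogen on the saturated chain changes the number at all.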